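Swapping the nitro group of compound 2 for hydroxy

This account rests on a few compounds, and the source may have more. Where it says the series, first, only, none or still open, it means among the compounds named here.

In a functional assay on SGC-7901 cells (Homo sapiens) for antiproliferative activity, read by MTT assay, with a stated time of 72 h (a higher number here means a weaker inhibitor, a lower number a stronger inhibitor), compound 1 (`COc1ccc(-c2ccsc2-c2cc(OC)c(OC)c(OC)c2)cc1`) gives 2740 nM and compound 2 (`COc1ccc(-c2ccsc2-c2cc(OC)c(OC)c(OC)c2)cc1[N+](=O)[O-]`) gives 10300 nM as the higher of the two numbers, marking the weaker inhibitor. Compound 3 (`COc1ccc(-c2ccsc2-c2cc(OC)c(OC)c(OC)c2)cc1O`) carries hydroxy in place of nitro on an aromatic carbon. Going by the values given here, only one measured step bears on this: nitro in place of hydrogen gave a 3.8-fold higher number from compound 1 to compound 2 (0.58 log units; beyond the scatter) and is modest, though beyond the scatter. Among the compounds with values here, since that step went upward, removing nitro should bring a drop in this assay at least as large, though no measured compound shows what hydroxy does. The expected change is (a 10-fold lower number from compound 2 to compound 3 (1.01 log units; beyond the scatter)) in size. For compound 3 the estimate is 1000 nM (range 100 nM to 6000 nM).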

Compound 3, half-maximal inhibitory concentration: 520 nM
The estimate for compound 3 lay 1.9-fold (0.28 log units) above the measured number; the range from low to high includes it.
By their numbers in this assay, from the lowest: compound 3; then compound 1; then compound 2.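

In this assay, hydroxy in place of nitro gives a 20-fold lower number from compound 2 to compound 3 (1.30 log units; beyond the scatter), and hydroxy in place of hydrogen gives a 5.3-fold lower number from compound 1 to compound 3 (0.72 log units; beyond the scatter). So a group added at this position, ortho to a methoxy group, does not always raise the number: nitro raised it, whereas hydroxy lowered it, leaving compound 3 the strongest inhibitor of the three. Nothing available explains why the two groups differ. Still open, from the compounds shown here alone, is whether an amine or a fluorine atom at this position would behave more like hydroxy or more like nitro.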